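Iodo in Place of Methyl: From Compound 2 to Compound 3

The source may report more compounds than this note shows. Statements on the series, on what has been measured and on what is new or still open speak of the compounds shown alone.

Within the data shown here, in an assay on HEK293 cells for inhibition of transient receptor potential cation channel subfamily V member 6 (Homo sapiens), read by FLIPR and calcium flux, with a stated time of 5 min (a lower number here means a stronger inhibitor, a higher number a weaker inhibitor), compound 2 `Cc1ccc([B-]2(c3ccccc3)[NH2+]CCO2)cc1` gives 18900 nM, the only actual number among the two values shown. Compound 1 `COc1ccccc1[B-]1(c2ccccc2OC)[NH2+]CCO1` gives in this assay only a limit, > 500000 nM. Compound 3 `Ic1ccc([B-]2(c3ccccc3)[NH2+]CCO2)cc1` is not yet measured; it differs from compound 2 by iodo in place of methyl on an aromatic carbon. Among the measured compounds shown here, no measured step of this kind exists, so its size is unknown; a modest move toward stronger inhibition, hardly beyond the scatter, is expected. For compound 3 the estimate in this assay is 10000 nM, between 3000 nM and 40000 nM. The expected step is a 1.9-fold lower number from compound 2 to compound 3 (0.28 log units; within the scatter).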

Compound 3, half-maximal inhibitory concentration: 5400 nM
Compound 3: middle estimate off by 1.9-fold (0.27 log units), on the high side, and the stated range covers the measured number.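

Among these compounds, this step gives the first reading of a change at the aromatic carbon para to a large group: in this assay the swap of methyl for iodo gives a 3.5-fold lower number from compound 2 to compound 3 (0.54 log units; beyond the scatter) and so lies beyond the scatter. The number at this carbon therefore depends on which of these two single-atom groups it carries. Nothing measured here accounts for the size of this step.

The compounds shown leave open how an amine, a carboxylic acid or a bromo group at this carbon would compare. They also leave open whether iodo in place of methyl would give a similar step on another core.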